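The source may report more compounds than this note shows. Statements on the series, on what has been measured and on what is new or still open speak of the compounds shown alone.

Measured compounds in a functional assay on Ehrlich cells (Mus musculus) for cytotoxicity, read by trypan blue exclusion, with a stated time of 2 h, tested at 100 ug/mL; a higher number here means a stronger effect of the compound at the concentration tested, a lower number a weaker effect:
compound 1 `CC(Cl)CC(=O)NC1=C(C#N)C(c2ccc(Cl)cc2Cl)C2=C(CCCC2=O)N1c1ccc(S(N)(=O)=O)cc1`: 60%
compound 2 `N#CC1=C(NC(=O)c2ccccc2)N(c2ccc(S(N)(=O)=O)cc2)C2=C(C(=O)CCC2)C1c1ccc(Cl)cc1Cl`: 75%
compound 3 `N#CC1=C(NC(=O)c2ccc([N+](=O)[O-])cc2)N(c2ccc(S(N)(=O)=O)cc2)C2=C(C(=O)CCC2)C1c1ccc(Cl)cc1Cl`: 70%

Compound 3 stands second highest of the three numbers. Its nearest neighbour is compound 2 at 75%, a gap within the scatter, and compound 1 at 60% is also within the scatter of compound 3. For the measured compounds named here, no compound in the set is set apart from all others beyond the scatter.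

Compound 4 `CN(C)c1ccc(/C=N/C2=C(C#N)C(c3ccc(Cl)cc3Cl)C3=C(CCCC3=O)N2c2ccc(S(N)(=O)=O)cc2)cc1` is not yet measured. It differs from compound 3 in this way: a group of 11 heavy atoms (9 carbon, 2 nitrogen; one six-membered aromatic ring of carbon only) in place of a group of 12 heavy atoms (7 carbon, 2 nitrogen, 3 oxygen; one six-membered aromatic ring of carbon only), on a double-bonded ring carbon.

Going by the values given here, three measured steps bear on the question, though none of them exchanges the carbonyl-bearing linkage for the incoming group. a number 15 percentage points higher from compound 1 to compound 2 (beyond the scatter); a number 10 percentage points higher from compound 1 to compound 3 (within the scatter); a number 5 percentage points lower from compound 2 to compound 3 (within the scatter). The last of these shows that the nitro group contributes nothing beyond the scatter, so its loss in compound 4 is not expected to matter. Among the compounds with values here, the replacement of the carbonyl linkage has no precedent in the set, which leaves the direction open.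

In this assay compound 4 is therefore expected near 65%, with a range from 45% to 85%. The expected step is a number 5 percentage points lower from compound 3 to compound 4 (within the scatter), not beyond the scatter.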

Compound 4, a percentage reported as activity, at one concentration (the size of the read-out at that concentration, not a potency): 40%
Beside the measured number, compound 4's estimate is 25 percentage points above it; the measured number lies below the stated range.
By their numbers in this assay, from the lowest: compound 4; then compounds 1, 3 and 2 (each within the scatter of the next, the first and the last beyond it).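

In this assay the substituent on the double-bonded ring carbon next to the ring nitrogen matters beyond the acyl part alone, since all three amides separate from compound 4 in the steps of a number 30 percentage points lower from compound 3 to compound 4 (beyond the scatter) and a number 35 percentage points lower from compound 2 to compound 4 (beyond the scatter) and a number 20 percentage points lower from compound 1 to compound 4 (beyond the scatter) in this series. Compounds 1, 2 and 3 vary only the group on the carbonyl carbon, with a number 15 percentage points higher from compound 1 to compound 2 (beyond the scatter) as the largest such step, whereas compound 4 alone has no carbonyl in this linkage and carries 0 hydrogen-bond donors in the entering group, so the link to the ring carbon, and not only the group at its far end, now appears as a variable tied to the read-out. No measurement here accounts for the lower number of compound 4.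

Compound 4 changes the linkage and the substituent on the aromatic ring together, so a benzamide carrying dimethylamino, or the same imine linkage with an unsubstituted phenyl or a 4-nitrophenyl, would be needed to assign the step to one of the two. From the compounds shown here alone, a free primary amine or an acetyl group on this ring carbon also remains open, and all these readings rest on a single concentration, which gives no potency.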